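Compound 4 and a series of limits

A few compounds are considered here, and "the series" means these few. Any claim that something is new, unique, unknown or untested is made for them only; others in the source may bear on it.

Measured so far in an ADME assay on MT4 cells (Homo sapiens) for cytotoxicity, read by MTT assay, with a stated time of 5 days (a higher number here means that more compound is tolerated, a lower number that less compound is tolerated), all three values being limits of the assay:
- compound 1 (`CCCNc1cc(Oc2c(OC)cc3cc(C#N)ccc3c2OC)nc(Nc2ccc(C#N)cc2)n1`) gives > 125000 nM as a limit
- compound 2 (`COc1cc2cc(C#N)ccc2c(OC)c1Oc1cc(NC2CCC2)nc(Nc2ccc(C#N)cc2)n1`) gives > 125000 nM as a limit
- compound 3 (`COc1cc2cc(C#N)ccc2c(OC)c1Oc1cc(NC2CCCC2)nc(Nc2ccc(C#N)cc2)n1`) gives > 125000 nM as a limit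

Compound 3 therefore has a limit and no true number. Among the compounds with values here, the series so far offers the limit of > 125000 nM in this assay, at which 3 of the 3 values shown sit, and nothing finer. Within the data shown here, compound 4 (`COc1cc2cc(C#N)ccc2c(OC)c1Oc1cc(NCC2CCOC2)nc(Nc2ccc(C#N)cc2)n1`) carries (oxolan-3-yl)methyl in place of cyclopentyl on a nitrogen on an aromatic ring as its one change. The steps a step that the two limits leave unreadable from compound 1 to compound 3 and a step that the two limits leave unreadable from compound 2 to compound 3 and a step that the two limits leave unreadable from compound 1 to compound 2 bear on this change, and none has a size to carry over. No step beyond the usual scatter is therefore expected in this assay for this change. The estimated move is a number no higher from compound 3 to compound 4 (the limit leaves the size open) in size. Compound 4 is expected to give an estimated 125000 nM within a likely range of 60000 nM to 250000 nM as its result.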

Compound 4, half-maximal cytotoxic concentration: > 125000 nM
Compound 4: no number, only a limit; the forecaster's own chance of this, stated with the estimate: 85%; the middle value sits exactly at the limit.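

No step can be read between compound 4 and compounds 1, 2 or 3, because all four share one assay limit: the limit of > 125000 nM in this assay, at which 4 of the 4 values shown sit.

The compounds shown leave open each compound's true half-maximal cytotoxic concentration, and whether swapping these groups changes it.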